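This account rests on a few compounds, and the source may have more. Where it says the series, first, only, none or still open, it means among the compounds named here.

Measured in a physicochemical assay for solubility; on this read-out lower numbers stand for lower solubility and higher numbers for higher solubility:
- compound 1 `O=C(c1ccc(Cl)cc1)N1CCC(NS(=O)(=O)c2cc(S(=O)(=O)c3ccccc3)ccc2C(F)(F)F)CC1` gives 3100 nM
- compound 2 `O=C(O)c1ccc(S(=O)(=O)N2CCC(NS(=O)(=O)c3cc(S(=O)(=O)c4ccccc4)ccc3C(F)(F)F)CC2)cc1` gives 12500 nM
- compound 3 `CC(C)(O)CCN1CCC(NS(=O)(=O)c2cc(S(=O)(=O)c3ccccc3)ccc2C(F)(F)F)CC1` gives 50000 nM

These three compounds share a core and differ only in the group on an amine nitrogen in a ring. Compound 3 has the highest number of the three. The closest comparison is a 4.0-fold higher number from compound 2 to compound 3 (0.60 log units; beyond the scatter), and the widest is a 16-fold higher number from compound 1 to compound 3 (1.21 log units; beyond the scatter). The remaining step is a 4.0-fold higher number from compound 1 to compound 2 (0.61 log units; beyond the scatter).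

Compound 4 `O=C([C@H]1CCNC1)N1CCC(NS(=O)(=O)c2cc(S(=O)(=O)c3ccccc3)ccc2C(F)(F)F)CC1` has not yet been measured. It carries (pyrrolidin-3-yl)carbonyl in place of 3-hydroxy-3-methylbutyl at that same nitrogen ((pyrrolidin-3-yl)carbonyl in place of 3-hydroxy-3-methylbutyl on an amine nitrogen in a ring).

All three measured steps change this place, so all of them bear on the new one, though none involves the incoming group. Compound 4 keeps a carbonyl on the nitrogen, as compound 1 does, and the step of a 16-fold higher number from compound 1 to compound 3 (1.21 log units; beyond the scatter) is large. However, a five-membered non-aromatic ring replaces the (4-chlorophenyl) part, and no measured compound carries such a ring. Compound 1 is therefore only a loose guide, and a fall as large as that step is not expected. A small downward move in this assay seems most likely, and the expected step is a 1.7-fold lower number from compound 3 to compound 4 (0.22 log units; within the scatter). For compound 4 the estimated value is 30000 nM, with an expected range from 10000 nM to 80000 nM.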

Compound 4, solubility: 25000 nM
For compound 4 the middle estimate is 1.2-fold (0.08 log units) above the measured one; the range from low to high includes it.
By their numbers in this assay, from the lowest: compound 1; then compounds 2, 4 and 3 (each within the scatter of the next, the first and the last beyond it).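

In this assay, compound 1 and compound 4 both keep a carbonyl on the amine nitrogen in a ring and differ only in what that carbonyl carries, and swapping 4-chlorophenyl for pyrrolidin-3-yl gives an 8.1-fold higher number from compound 1 to compound 4 (0.91 log units; beyond the scatter), so the low number of compound 1 does not go with the carbonyl alone. The comparisons with the two groups that have no carbonyl on that nitrogen do not separate compound 4 from either: a 2.0-fold lower number from compound 3 to compound 4 (0.30 log units; within the scatter) and a 2.0-fold higher number from compound 2 to compound 4 (0.30 log units; within the scatter) both lie within the scatter, even though compound 2 and compound 3 lie beyond the scatter of each other. No supporting measurement is available to explain any of these steps.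

From the compounds shown here alone, it remains open whether the step from compound 1 depends on the nitrogen in the new ring or on the ring itself; a cyclopentylcarbonyl group, with carbon in place of that nitrogen, would tell the two apart. Also open, going by these compounds, is how the mirror-image form at the defined stereocentre of compound 4 would read in this assay.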